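Notes on replacing the halophenyl group on the carbonyl

The source may hold more compounds than are shown below. What is called first, only, known or untested is meant among the compounds shown, and "the series" means these compounds.

In a functional assay on MCF7 cells (Homo sapiens) for inhibition, read by MTT assay (a higher number here means a weaker inhibitor, a lower number a stronger inhibitor), compound 1 (`COc1cc2ncnc(Nc3ccc(NC(=O)c4ccccc4F)cc3)c2cc1OC`) gives 11000 nM and compound 2 (`COc1cc2ncnc(Nc3ccc(NC(=O)c4cccc(F)c4)cc3)c2cc1OC`) gives 13600 nM with the two values within the scatter of each other. Compound 3 (`COc1cc2ncnc(Nc3ccc(NC(=O)c4ccc(Cl)cc4)cc3)c2cc1OC`) is not yet measured and carries 4-chlorophenyl in place of 3-fluorophenyl on a carbonyl carbon. Going by the values given here, the sole measured step, a 1.2-fold higher number from compound 1 to compound 2 (0.09 log units; within the scatter) and within the scatter, does not involve 4-chlorophenyl and so guides only loosely. In this assay no shift beyond the scatter is therefore expected (a 1.1-fold lower number from compound 2 to compound 3 (0.05 log units; within the scatter)). Compound 3 is expected at 12000 nM with an estimated range of 5000 nM to 28000 nM for now.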

Compound 3, half-maximal inhibitory concentration: 30000 nM
The estimate for compound 3 lay 2.5-fold (0.40 log units) below the measured number, outside the stated range (above it).
By their numbers in this assay, from the lowest: compounds 1 and 2 (each within the scatter of the next); then compound 3.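

In this assay the group on the carbonyl carbon does matter: 4-chlorophenyl gives a 2.2-fold higher number from compound 2 to compound 3 (0.34 log units; beyond the scatter) and also a 2.7-fold higher number from compound 1 to compound 3 (0.44 log units; beyond the scatter), both modest steps, whereas the two fluorophenyl compounds stayed within the scatter of each other. This position therefore tolerates some changes of the halophenyl group without a shift, but not all of them. No measurement at hand bears on the reason for this shift.

Compound 3 changes both the halogen and the name of the phenyl group at once, so the two changes cannot be told apart. As far as these compounds go, whether 3-chlorophenyl, 4-fluorophenyl or an unsubstituted phenyl would follow compound 3 or the fluorophenyl pair remains open.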